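Another Ring-Bearing Group on the Shared Core

The compounds below may be only part of what the source reports. "The series", "measured", "known", "first", "only" and "open" are said of these compounds alone.

Compound 1 `COc1cc(OC)c(-c2coc3cc(OCC=C(C)C)ccc3c2=O)cc1OC` gives 680 nM in a functional assay on HCT-116 cells (Homo sapiens) for antiproliferative activity, read by MTT assay, with a stated time of 24 h; a lower number here means a stronger inhibitor, a higher number a weaker inhibitor.
Compound 2 `COc1cc(OC)c(-c2coc3cc(OCc4ccccc4F)ccc3c2=O)cc1OC` gives 2900 nM in this assay.
Compound 3 `COc1cc(OC)c(-c2coc3cc(OCc4ccccc4C)ccc3c2=O)cc1OC` gives 2900 nM in this assay.

Of the three measured compounds, compound 1 stands at the lowest number in this assay. Exchanging its 2-methylprop-1-en-1-yl group for 2-fluorophenyl gives a 4.3-fold higher number from compound 1 to compound 2 (0.63 log units; beyond the scatter), and exchanging it for 2-methylphenyl gives a 4.3-fold higher number from compound 1 to compound 3 (0.63 log units; beyond the scatter). Between the two ring-bearing analogues there is no change at the digits printed from compound 2 to compound 3 (within the scatter).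

Compound 4 `COc1cc(OC)c(-c2coc3cc(OCc4ccc([N+](=O)[O-])cc4)ccc3c2=O)cc1OC` has not yet been measured. It differs from compound 1 in one place: 4-nitrophenyl in place of 2-methylprop-1-en-1-yl on a saturated chain carbon bound to an oxygen on an aromatic ring.

Both measured steps that bear on this change put a six-membered ring of carbon only onto the same saturated chain carbon in place of the open chain, and both moved the number up by the same modest amount. Among the measured compounds shown here, compound 4 repeats that kind of exchange, though the nitro substituent on its ring has no counterpart among the measured compounds, so nothing is known about its own contribution. Compound 4 is therefore expected to show a step of about the same size and direction, a 4.0-fold higher number from compound 1 to compound 4 (0.60 log units; beyond the scatter). The estimate for compound 4 in this assay is 2700 nM, with a range from 1000 nM to 7500 nM.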

Compound 4, half-maximal inhibitory concentration: > 10000 nM
Compound 4: no number, only a limit (the forecaster's own chance of this, stated with the estimate: 3%); at least 3.7-fold (0.56 log units) between middle value and limit.
By their numbers in this assay, from the lowest: compound 1; then compounds 2 and 3 (each within the scatter of the next). At a limit, above all of these: compound 4.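

For compound 4 the reading in this assay is a limit of the assay and not a number: the limit of > 10000 nM in this assay, at which 1 of the 4 values shown sits. Even so, replacing 2-methylprop-1-en-1-yl with 4-nitrophenyl on the saturated chain carbon gives an at least 14-fold higher number from compound 1 to compound 4 (1.16 log units; beyond the scatter), so a carbon-only aromatic ring at this place does not set a single step size, as the two earlier exchanges alone might have suggested. The exchanges from one ring-bearing group to another give an at least 3.4-fold higher number from compound 2 to compound 4 (0.53 log units; beyond the scatter) and an at least 3.4-fold higher number from compound 3 to compound 4 (0.53 log units; beyond the scatter), which shows that the choice of ring substituent can matter at this position, something the identical values of the earlier ring-bearing pair gave no sign of.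

The 4-nitrophenyl group differs from 2-fluorophenyl and 2-methylphenyl in both the substituent and its numbered ring position, so the compounds shown do not separate the effect of the nitro group from that of its location, and the limit leaves the full size of each step unknown. Where an unsubstituted phenyl, 2-nitrophenyl or 4-aminophenyl group would fall at this place remains open.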